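This account rests on a few compounds, and the source may have more. Where it says the series, first, only, none or still open, it means among the compounds named here.

Measured in an assay on HEK293 cells for displacement of a labelled ligand from 5-hydroxytryptamine receptor 6 (Homo sapiens), read by scintillation counting; on this read-out lower numbers stand for stronger inhibition and higher numbers for weaker inhibition:
- compound 1 `COc1ccc2c(c1)c(C1=CCNCC1)cn2S(=O)(=O)c1ccc2cccnc2c1` gives 2 nM
- compound 2 `COc1ccc2c(c1)c(C1CCNCC1)cn2S(=O)(=O)c1ccc2cccnc2c1` gives 30 nM

Among these two numbers compound 2 stands highest, that is, it binds most weakly; its only neighbour is compound 1, and the step of a 15-fold higher number from compound 1 to compound 2 (1.18 log units; beyond the scatter) is a large one, beyond the scatter.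

Compound 3 `COc1ccc2c(c1)c(C1=CCN(C)CC1)cn2S(=O)(=O)c1ccc2cccnc2c1` is not yet measured. It differs from compound 2 in one place: a group of 7 heavy atoms (6 carbon, 1 nitrogen; one six-membered non-aromatic ring with 1 hetero atom) in place of a group of 6 heavy atoms (5 carbon, 1 nitrogen; one six-membered non-aromatic ring with 1 hetero atom), on an aromatic carbon. The entering group brings back a double bond outside aromatic rings, as compound 1 has, and has no hydrogen-bond donor.

Among the measured compounds shown here, only one measured step bears on this change: a 15-fold higher number from compound 1 to compound 2 (1.18 log units; beyond the scatter), where the ring with the double bond outside aromatic rings was replaced by the fully saturated piperidin-4-yl and the number rose sharply. For the measured compounds named here, compound 3 reverses that part of the change while adding a methyl on the ring nitrogen, for which no measured step exists here.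

The expected step is therefore a 7.5-fold lower number from compound 2 to compound 3 (0.88 log units; beyond the scatter) in this assay, a clear fall in the number. For compound 3 the estimate is 4 nM, with a range from 1.5 nM to 12 nM.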

Compound 3, inhibition constant: 82 nM
The estimate for compound 3 lay 21-fold (1.31 log units) below the measured number; the whole stated range lies below it.
By their numbers in this assay, from the lowest: compound 1; then compound 2; then compound 3.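

In this assay, putting a methyl on the ring nitrogen of the group carrying the double bond gives a 41-fold higher number from compound 1 to compound 3 (1.61 log units; beyond the scatter), a large step, so at this position the ring nitrogen tolerates even this small addition poorly. The double bond therefore does not favour binding on its own terms: with the methyl present, the exchange of the piperidin-4-yl for the new group gives a 2.7-fold higher number from compound 2 to compound 3 (0.44 log units; beyond the scatter), a modest step in the opposite direction from what the earlier pair suggested, and the benefit seen for the double bond in compound 1 holds only for the ring with the free amine hydrogen. No measurement here explains why the methyl costs so much binding.

The compounds shown leave open how a methyl on the nitrogen of the saturated piperidin-4-yl would behave, and so whether the effects of the double bond and the methyl simply add or depend on each other. They also leave open whether other groups on that nitrogen, such as an ethyl, a benzyl or an acetyl, would fare the same as methyl.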